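Removing the nitro group from compound 2

A few compounds are considered here, and "the series" means these few. Any claim that something is new, unique, unknown or untested is made for them only; others in the source may bear on it.

The compounds measured so far in a functional assay on HCT-116 cells (Homo sapiens) for inhibition, read by sulforhodamine B assay, with a stated time of 48 h, tested at 50 uM (a lower number here means less inhibition of growth, a higher number more inhibition of growth at the concentration tested), are these:
- compound 1 `CCCOc1ccc([C@@H]2CC(=O)c3cc(CC=C(C)C)c(OC)cc3O2)cc1` gives 63%
- compound 2 `COc1cc2c(cc1CC=C(C)C)C(=O)C[C@@H](c1ccc(Oc3cccc([N+](=O)[O-])c3)cc1)O2` gives 46%
- compound 3 `COc1ccc([C@@H]2C/C(=N/OCc3cn(-c4ccc(C(N)=O)cc4)nn3)c3cc(CC=C(C)C)c(OC)cc3O2)cc1` gives 100%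

Compound 2 holds the lowest of these three numbers, and compound 1 and compound 3 both stand higher, beyond the scatter. Compound 4 `COc1cc2c(cc1CC=C(C)C)C(=O)C[C@@H](c1ccc(Oc3ccccc3)cc1)O2` differs from compound 2 by one change, (hydrogen in place of nitro on an aromatic carbon), which is hydrogen in place of nitro on an aromatic carbon and turns 3-nitrophenoxy into phenoxy. For the measured compounds named here, only one measured step bears on this: a number 17 percentage points lower from compound 1 to compound 2 (beyond the scatter), with 3-nitrophenyl in place of propyl on an oxygen on an aromatic ring. Going by the values given here, that step exchanged a whole group, so it does not separate the nitro from the ring that carries it, and no measured pair isolates the nitro alone. Only a small rise is therefore expected in this assay, smaller than that step. The estimated change is a number 6 percentage points higher from compound 2 to compound 4 (within the scatter) and no more. For compound 4 the expected value is 52%, with 35% to 70% as the expected range.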

Compound 4, percent growth inhibition at one concentration: 76%
Compound 4: the middle estimate sits 24 percentage points below what was measured, outside the stated range (above it).
By their numbers in this assay, from the lowest: compound 2; then compound 1; then compound 4; then compound 3.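

In this assay, for the compounds shown here, the change from 3-nitrophenoxy to phenoxy gives a number 30 percentage points higher from compound 2 to compound 4 (beyond the scatter), and this is the first step to isolate the nitro alone. Set against a number 17 percentage points lower from compound 1 to compound 2 (beyond the scatter), phenyl in place of propyl on the same oxygen gives a number 13 percentage points higher from compound 1 to compound 4 (beyond the scatter), so the two steps run in opposite directions and the lower number of compound 2 goes with the nitro, not with the aromatic ring that carries it. The data on hand give no reason for this difference.

Going by these compounds, whether an amine or a carboxylic acid at the same place on the ring would also lower the number as the nitro does remains open. So does whether a longer chain in place of propyl on that oxygen would match or pass the phenyl of compound 4.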